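The source may report more compounds than this note shows. Statements on the series, on what has been measured and on what is new or still open speak of the compounds shown alone.

Measured compounds:
compound 1, `NC(=S)N/N=C/c1ccc2ccccc2n1`: 960 nM
compound 2, `COc1cccc(NC(=S)N/N=C/c2ccc3ccccc3n2)c1`: 74500 nM

In a functional assay on HeLa cells (Homo sapiens) for antiproliferative activity, read by sulforhodamine B assay, with a stated time of 72 h (on this read-out lower numbers stand for stronger inhibition and higher numbers for weaker inhibition), compound 2 stands highest of the two numbers; its nearest neighbour is compound 1, and the step of a 78-fold higher number from compound 1 to compound 2 (1.89 log units; beyond the scatter) is large. Compound 3, `Cc1ccccc1NC(=S)N/N=C/c1ccc2ccccc2n1`, keeps the shared core and differs from compound 2 by 2-methylphenyl in place of 3-methoxyphenyl on an amide-type nitrogen. Among the compounds with values here, the only measured step concerns the entry of an aryl group onto the nitrogen, not an exchange of one aryl group for another, so it bears on compound 3 only loosely. Compound 3 is expected to stay near compound 2 in this assay, with a step of a 1.9-fold lower number from compound 2 to compound 3 (0.27 log units; within the scatter) that may fall within the scatter. Compound 3 is estimated at 40000 nM, range 8000 nM to 150000 nM.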

Compound 3, half-maximal inhibitory concentration: > 100000 nM
Compound 3: a limit, no number (the forecaster's own chance of this, stated with the estimate: 10%); middle value at least 2.5-fold (0.39 log units) away from the limit.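

In this assay compound 3 gives a limit and not a number: the limit of > 100000 nM in this assay, at which 1 of the 3 values shown sits. With 2-methylphenyl in place of hydrogen on the amide-type nitrogen, a second aryl group also gives a large rise (an at least 100-fold higher number from compound 1 to compound 3 (2.01 log units; beyond the scatter)), so the loss seen with 3-methoxyphenyl is not confined to that one group. The two aryl groups cannot be ranked against each other (an at least 1.3-fold higher number from compound 2 to compound 3 (0.12 log units; that floor lies within the scatter)).

Open, from the compounds shown here alone, is whether a methyl group or a longer alkyl chain on this nitrogen would stay close to compound 1 960 nM.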